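The source may hold more compounds than are shown below. What is called first, only, known or untested is meant among the compounds shown, and "the series" means these compounds.

In an ADME assay on HEK-293T cells (Homo sapiens) for cytotoxicity, read by MTT assay, with a stated time of 24 h (a higher number here means that more compound is tolerated, a lower number that less compound is tolerated), compound 2 (`Cc1ccc(-c2nn(-c3ccccc3)cc2-c2nc3ccccc3n2S(=O)(=O)c2ccccc2)cc1`) gives 138000 nM. That value lies within the scatter of the two other measured compounds: compound 1 (`FC(F)(F)c1ccc(-c2nn(-c3ccccc3)cc2-c2nc3ccccc3[nH]2)cc1`) gives 167000 nM and compound 3 (`Cc1ccc(-c2nn(-c3ccccc3)cc2-c2nc3ccccc3n2S(=O)(=O)c2ccc(C)cc2)cc1`) gives 79300 nM. The next compound, compound 4 (`Cc1ccc(-c2nn(-c3ccccc3)cc2-c2nc3ccccc3n2S(=O)(=O)c2cc(C)ccc2C)cc1`), has not yet been measured. It departs from compound 2 on the sulfonyl group, with 2,5-dimethylphenyl in place of phenyl on a sulfonyl sulfur. Within the data shown here, only one measured step bears on this change. That step, a 1.7-fold lower number from compound 2 to compound 3 (0.24 log units; within the scatter), came with methyl in place of hydrogen on an aromatic carbon, and it is small. Among the measured compounds shown here, no measured compound yet carries the 2,5-dimethylphenyl group, so the guide is indirect. On the evidence of that single step, a modest move toward a lower number in this assay, not clearly beyond the scatter, is expected for compound 4. The expected change is a 1.6-fold lower number from compound 2 to compound 4 (0.21 log units; within the scatter). For compound 4 the estimated value is 85000 nM, with an expected range of 35000 nM to 170000 nM.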

Compound 4, half-maximal cytotoxic concentration: 82200 nM
Compound 4: the middle estimate sits 1.0-fold (0.01 log units) above what was measured; the range from low to high includes it.
By their numbers in this assay, from the lowest: compounds 3, 4, 2 and 1 (each within the scatter of the next, the first and the last beyond it).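

In this assay the change from phenyl to 2,5-dimethylphenyl on a sulfonyl sulfur gives a 1.7-fold lower number from compound 2 to compound 4 (0.23 log units; within the scatter) and so shows that a ring with two methyl groups at this position stays within the scatter of the unsubstituted phenyl. Set against 4-methylphenyl, the same group gives a 1.0-fold higher number from compound 3 to compound 4 (0.02 log units; within the scatter) and so the ring with one methyl group and the ring with two cannot be told apart here. The three sulfonyl compounds, compound 2, compound 3 and compound 4, therefore all lie within the scatter of each other. As far as these compounds go, whether an aryl ring carrying an amine or a carboxylic acid, or a longer alkyl chain in place of the ring on the sulfonyl sulfur, would move the number beyond the scatter remains open. No measurement shown here offers an explanation for these small steps.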